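Trifluoromethyl for bromo on the benzylamine aryl ring

A few compounds are considered here, and "the series" means these few. Any claim that something is new, unique, unknown or untested is made for them only; others in the source may bear on it.

Measured compounds and their values in a functional assay on 1321-N1 cells for agonist activity at Free fatty acid receptor 1 (Homo sapiens), read by calcium flux; a higher number here means that more compound is needed for the effect, a lower number that less compound is needed:
compound 1, `O=C(O)CCc1ccc(NCc2ccccc2)cc1`, 759 nM
compound 2, `O=C(O)CCc1ccc(CNc2ccccc2)cc1`, 21400 nM
compound 3, `O=C(O)CCc1ccc(NCc2cccc(Br)c2)cc1`, 174 nM

Of the three measured compounds, compound 3 gives the lowest number in this assay. The nearest is compound 1, with 759 nM; the step from compound 1 to compound 3 is a 4.4-fold lower number from compound 1 to compound 3 (0.64 log units; beyond the scatter). Among the measured compounds shown here, the furthest is compound 2, whose value of 21400 nM sits far above the other two, though no single-point step links compound 2 to compound 3.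

Compound 4, `O=C(O)CCc1ccc(NCc2cccc(C(F)(F)F)c2)cc1`, has not yet been measured. It differs from compound 3 in one place: trifluoromethyl in place of bromo on an aromatic carbon. For the measured compounds named here, the only measured step that bears on this position is the one from compound 1 to compound 3, which shows that a substituent at this aromatic carbon, in place of hydrogen, lowers the number beyond the scatter. Going by the values given here, no measured pair shows how one substituent there compares with another, so the size of the change from bromo to trifluoromethyl is unknown. The expected step from compound 3 to compound 4 is therefore a 1.1-fold higher number from compound 3 to compound 4 (0.06 log units; within the scatter), a step within the scatter rather than a further gain. For compound 4 in this assay the estimate is 200 nM, with a range from 70 nM to 600 nM.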

Compound 4, half-maximal effective concentration: 186 nM
The estimate for compound 4 lay 1.1-fold (0.03 log units) above the measured number; the range from low to high includes it.
By their numbers in this assay, from the lowest: compounds 3 and 4 (each within the scatter of the next); then compound 1; then compound 2.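

In this assay, exchanging bromo for trifluoromethyl at this aromatic carbon gives a 1.1-fold higher number from compound 3 to compound 4 (0.03 log units; within the scatter), so the two groups cannot be told apart here, although one brings 1 heavy atom and the other 4. Trifluoromethyl in place of hydrogen gives a 4.1-fold lower number from compound 1 to compound 4 (0.61 log units; beyond the scatter), and bromo in place of hydrogen gives a 4.4-fold lower number from compound 1 to compound 3 (0.64 log units; beyond the scatter), both beyond the scatter. The gain over compound 1 at this carbon is therefore not particular to bromo, though only these two groups show it.

On these data alone, whether it extends to other groups at this carbon, such as a nitrile, a methoxy group or an amine, or to trifluoromethyl on another ring carbon, remains open. Nothing given here accounts for the match between bromo and trifluoromethyl.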